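The source may report more compounds than this note shows. Statements on the series, on what has been measured and on what is new or still open speak of the compounds shown alone.

Measured compounds:
Compound 1 `O=S(=O)(Nc1ccc(-c2nc3ccccc3o2)cc1)c1cccs1`; in an ADME assay on HEK293 cells (Homo sapiens) for cytotoxicity, read by resazurin assay, with a stated time of 48 h (a higher number here means that more compound is tolerated, a lower number that less compound is tolerated), compound 1 gives > 100000 nM, which is a limit of the assay.
Compound 2 `Cc1cccc(S(=O)(=O)Nc2ccc(-c3nc4ccccc4o3)cc2)c1`; in this assay compound 2 gives > 100000 nM, also a limit of the assay.
Compound 3 `C=Cc1ccc(S(=O)(=O)Nc2ccc(-c3nc4ccccc4o3)cc2)cc1`; in this assay compound 3 gives > 100000 nM, again a limit of the assay.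

Compound 3 therefore stands at the limit of this assay, and every measured value in the series sits there as well (the limit of > 100000 nM in this assay, at which 3 of the 3 values shown sit). The steps between the measured compounds cannot be read: a step that the two limits leave unreadable from compound 1 to compound 2, a step that the two limits leave unreadable from compound 1 to compound 3 and a step that the two limits leave unreadable from compound 2 to compound 3 are all hidden by the limit, so none of the three changes on the sulfonyl sulfur can be sized.

Compound 4 `O=S(=O)(Nc1ccc(-c2nc3ccccc3o2)cc1)c1ccc(O)cc1` differs from compound 3 as follows: hydroxy in place of vinyl on an aromatic carbon. Going by the values given here, no measured step bears readably on a change of this kind; the only usable fact is that all three measured compounds sit at the limit (the limit of > 100000 nM in this assay, at which 3 of the 3 values shown sit). The expectation for compound 4 is accordingly a value at that limit, with no step beyond the scatter expected, which means an expected step that the limit leaves unreadable from compound 3 to compound 4. For compound 4 the estimated value in this assay is 150000 nM, with a range from 60000 nM to 400000 nM.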

Compound 4, half-maximal cytotoxic concentration: > 100000 nM
Compound 4: no number, only a limit; the forecaster's own chance of this, stated with the estimate: 85%; the middle value is on the limit's open side.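

Compound 4 also sits at a limit of this assay, so its steps to compound 1, compound 2 and compound 3 cannot be read, and no new step emerges: the limit of > 100000 nM in this assay, at which 4 of the 4 values shown sit.

The compounds shown leave open whether any change on the sulfonyl sulfur alters cytotoxicity in this assay, and by how much.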